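The source may hold more compounds than are shown below. What is called first, only, known or untested is meant among the compounds shown, and "the series" means these compounds.

Compound 1 `CC(C)(C)Cc1csc(N)c1C(=O)c1ccc(Cl)cc1` gives 5% in an assay on CHO cells for displacement of a labelled ligand from adenosine receptor A3 (Homo sapiens), read by scintillation counting, tested at 10 uM; a lower number here means less inhibition, a higher number more inhibition at the concentration tested (going by the name of the read-out).
Compound 2 `CC(C)(C)Cc1c(-c2cccnc2)sc(N)c1C(=O)c1ccc(Cl)cc1` gives 1% in this assay.
Compound 3 `Cc1ccccc1-c1sc(N)c(C(=O)c2ccc(Cl)cc2)c1CC(C)(C)C` gives 1% in this assay.

All three numbers are small, and none of the steps between them reaches beyond the scatter. Compound 3 sits level with compound 2 at the digits shown, and together they hold the lowest numbers of the three; the step of no change at the digits printed from compound 2 to compound 3 (within the scatter) is flat, and the step of a number 4 percentage points lower from compound 1 to compound 3 (within the scatter) is also within the scatter. Compound 4 `CC(C)(C)Cc1c(-c2ccccc2)sc(N)c1C(=O)c1ccc(Cl)cc1` differs from compound 3 by a single small change: hydrogen in place of methyl on an aromatic carbon. For the measured compounds named here, no measured step removes a methyl from such a ring, so the change has no direct precedent here. What the three steps do show is that the group attached at that aromatic carbon of the shared core — hydrogen in compound 1, pyridin-3-yl in compound 2, 2-methylphenyl in compound 3 — made no difference beyond the scatter, as a number 4 percentage points lower from compound 1 to compound 2 (within the scatter) and a number 4 percentage points lower from compound 1 to compound 3 (within the scatter) are both within it. A trimmed version of that same group is therefore expected to behave alike, with the estimated step of a number 1 percentage points higher from compound 3 to compound 4 (within the scatter) staying inside the scatter. Compound 4 is estimated at 2%, in a range from 0% to 10%.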

Compound 4, a percentage reported as inhibition, at one concentration (the size of the read-out at that concentration, not a potency): 1%
Beside the measured number, compound 4's estimate is 1 percentage points above it, and the stated range covers the measured number.
By their numbers in this assay, from the lowest: compounds 2, 3, 4 and 1 (each within the scatter of the next).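

Taking the methyl off the 2-methylphenyl group, which leaves phenyl, is the first change made within the attached ring rather than an exchange of the whole group, and in this assay it gives no change at the digits printed from compound 3 to compound 4 (within the scatter). Phenyl also reads the same as pyridin-3-yl, with the step of no change at the digits printed from compound 2 to compound 4 (within the scatter), and setting phenyl on the core of compound 1 gives a number 4 percentage points lower from compound 1 to compound 4 (within the scatter), so hydrogen, pyridin-3-yl, 2-methylphenyl and phenyl at this aromatic carbon all stand within the scatter of one another. Across these four compounds, neither the methyl nor the group at this position moves the number beyond the scatter at the concentration tested, and no further measurement is available that bears on this result.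

The compounds shown leave open whether a different kind of substituent on the phenyl ring, such as an amine or a carboxylic acid, or a longer chain at the same aromatic carbon, would carry the number beyond the scatter. Going by these compounds, the rest of the shared core is the same in all four compounds, so what a change elsewhere would do in this assay also remains open.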